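The compounds below may be only part of what the source reports. "The series", "measured", "known", "first", "only" and "open" are said of these compounds alone.

In a functional assay on cells (Platelet, Homo sapiens) for inhibition (on this read-out higher numbers stand for weaker inhibition and lower numbers for stronger inhibition), none of the three measured compounds gives a number. Compound 1 (`CCOC(=O)c1ccc(-c2nn(C)c3ccccc23)cc1`) stands only at the limit of > 10000 nM. Compound 2 (`CCCn1nc(-c2ccc(C(=O)OCC)cc2)c2ccccc21`) also stands only at a limit, > 10000 nM. Compound 3 (`O=C(O)c1ccc(-c2nn(Cc3ccccc3)c3ccccc23)cc1`) is likewise known only as a limit, > 10000 nM.

Compound 4 (`CC(C)OC(=O)c1ccc(-c2nn(Cc3ccccc3)c3ccccc23)cc1`) differs from compound 3 by isopropyl in place of hydrogen on an oxygen next to a carbonyl group, so carboxy becomes isopropoxycarbonyl. Within the data shown here, the sole measured step, a step that the two limits leave unreadable from compound 1 to compound 2, lies at another place and cannot be sized, so the expectation rests on the structural change alone. The expected step, toward stronger inhibition in this assay, is an at least 5.0-fold lower number from compound 3 to compound 4 (0.69 log units; beyond the scatter). Compound 4 is estimated at 2000 nM, with an expected range of 200 nM to 10000 nM.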

Compound 4, half-maximal inhibitory concentration: > 10000 nM
Compound 4: no number, only a limit; the forecaster's own chance of this, stated with the estimate: 35%; middle value at least 5.0-fold (0.69 log units) from the limit.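

Compound 3 and compound 4 both stand only at a limit in this assay, so no step between them can be read: the limit of > 10000 nM in this assay, at which 4 of the 4 values shown sit.

The compounds shown leave open how strongly any of them inhibits in this assay, and whether carboxy or isopropoxycarbonyl makes any difference there.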